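Cyano for Trifluoromethyl: An Expected Thermal Shift Step

This account rests on a few compounds, and the source may have more. Where it says the series, first, only, none or still open, it means among the compounds named here.

Measured in an assay on isolated protein for inhibition of STE20-like serine/threonine-protein kinase (Homo sapiens), read by thermal shift assay, tested at 10 uM; on this read-out higher numbers stand for stronger stabilisation of the target against heat and lower numbers for weaker stabilisation of the target:
Compound 1, `CC(C)(C)c1cc(NC(=O)Nc2cc(C(F)(F)F)cc(C(F)(F)F)c2)n(C(C)(C)C)n1`, gives -0.2 degrees C
Compound 2, `CC(C)(C)c1cc(NC(=O)Nc2ccc(Cl)cc2)n(-c2ccc(C(F)(F)F)cc2)n1`, gives 0.7 degrees C

In this assay compound 2 and compound 1 lie within the usual scatter of each other, so neither stands apart from the other. Compound 3, `CC(C)(C)c1cc(NC(=O)Nc2ccc(Cl)cc2)n(-c2ccc(C#N)cc2)n1`, differs from compound 2 by cyano in place of trifluoromethyl on an aromatic carbon. Going by the values given here, no measured pair carries this change, so there is nothing to support a step in this assay in either direction; the expectation is a step no larger than the scatter. Compound 3 is expected to give about 0.5 degrees C, between -0.8 degrees C and 1.8 degrees C. The estimated step is a number 0.20 degrees C lower from compound 2 to compound 3 (within the scatter).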

Compound 3, shift of the target's melting temperature: 1.6 degrees C
Estimate against measurement, compound 3: 1.1 degrees C below; the measured number falls inside the stated range.
By their numbers in this assay, from the lowest: compounds 1, 2 and 3 (each within the scatter of the next, the first and the last beyond it).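

In this assay, the change from 4-(trifluoromethyl)phenyl to 4-cyanophenyl is a number 0.90 degrees C higher from compound 2 to compound 3 (within the scatter), so this position accepts cyano, with fewer heavy atoms and a hydrogen-bond acceptor, without a step beyond the scatter. Going by these compounds alone, this is the first measured pair to isolate a change at this position. Nothing measured here accounts for the step.

As far as these compounds go, whether an amine or a carboxylic acid at this position would move the number beyond the scatter remains open. So does whether the same change would give a similar step with a methoxy group in place of the chlorine.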